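Carboxy in place of propylamino on the shared core

This account rests on a few compounds, and the source may have more. Where it says the series, first, only, none or still open, it means among the compounds named here.

Measured so far:
compound 1, `Cc1cccnc1-c1ccc(C(=O)Nc2ccc(F)cc2)cc1`: > 4000 nM in a functional assay for antagonist activity at transient receptor potential cation channel subfamily V member 1 (Rattus norvegicus); a lower number here means a stronger inhibitor, a higher number a weaker inhibitor
compound 2, `CCCNc1cccnc1-c1ccc(C(=O)Nc2ccc(C(C)(C)C)cc2)cc1`: 37 nM in this assay

The value of compound 1, > 4000 nM, is a limit of the assay and not a number. Among the compounds with values here, compound 2 gives 37 nM in this assay, the only numerical value in the set. Within the data shown here, the one other value present is the limit of compound 1, as noted in the limit of > 4000 nM in this assay, at which 1 of the 2 values shown sits. Among the measured compounds shown here, compound 1 and compound 2 differ in more than one place, so no single measured step is available to calibrate the series.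

Compound 3, `CC(C)(C)c1ccc(NC(=O)c2ccc(-c3ncccc3C(=O)O)cc2)cc1`, is to be measured in this assay. Relative to compound 2 the change is carboxy in place of propylamino on an aromatic carbon. For the measured compounds named here, with no measured step at hand, the expectation rests on the change alone: a loss of potency well beyond the scatter is expected, with the step estimated at a 41-fold higher number from compound 2 to compound 3 (1.61 log units; beyond the scatter). For compound 3 the value is estimated at 1500 nM, with a range from 300 nM to 6000 nM, and a real chance that only a limit is returned.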

Compound 3, half-maximal inhibitory concentration: 560 nM
Compound 3: middle estimate off by 2.7-fold (0.43 log units), on the high side; the range from low to high includes it.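

Within this assay, carboxy in place of propylamino on an aromatic carbon gives a 15-fold higher number from compound 2 to compound 3 (1.18 log units; beyond the scatter) and provides the first single-place comparison in the series, showing that the group at this position, ortho to a large group and two atoms from the ring nitrogen, strongly affects potency. Carboxy and propylamino have the same computed counts of hydrogen-bond donors and acceptors and no net charge, so those counts do not separate the two compounds. Compound 3 gives a number and not a limit, so this step can be read in full, while the one limit in the set stays with compound 1: the limit of > 4000 nM in this assay, at which 1 of the 3 values shown sits.

The two groups differ in more than one respect, and the data give no reason for the step. Open questions are where a methyl ester, a primary amine or a longer alkylamino chain at this position would fall relative to compound 2 and compound 3, and whether the step would carry over to the amide part of compound 1.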